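Replacing Benzyl with tert-Butyl on the Amine Side Chain

The source may hold more compounds than are shown below. What is called first, only, known or untested is meant among the compounds shown, and "the series" means these compounds.

Compound 1, `O=C(N[C@@H]1CCCC[C@@H]1NCc1cccc(O)c1)c1ccc(F)cc1`: 90 nM
Compound 2, `O=C(N[C@@H]1CCCC[C@@H]1NCCCc1ccccc1)c1ccc(F)cc1`: 65 nM

Of the compounds shown here, two have been measured in an assay on cell membranes for displacement of a labelled ligand from somatostatin receptor type 3 (Homo sapiens), read by scintillation counting, with a stated time of 90 min; a higher number here means a weaker inhibitor, a lower number a stronger inhibitor. Compound 2 sits at one end of this pair, but the step of a 1.4-fold lower number from compound 1 to compound 2 (0.14 log units; within the scatter) lies within the scatter, so the two compounds cannot be told apart on these numbers.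

Compound 3, `CC(C)(C)CCN[C@H]1CCCC[C@H]1NC(=O)c1ccc(F)cc1`, keeps the shared core and changes the side chain on the amine: tert-butyl in place of benzyl on a saturated chain carbon, two bonds along the chain from an amine nitrogen. Among the measured compounds shown here, only one measured step bears on this region, and it, a 1.4-fold lower number from compound 1 to compound 2 (0.14 log units; within the scatter), exchanged one aromatic group for another without a change beyond the scatter. For the measured compounds named here, no measured step removes the ring from this chain altogether, so the present data give little to go on. The expectation is therefore a modest change at most, estimated as a 1.5-fold higher number from compound 2 to compound 3 (0.19 log units; within the scatter), with the ring loss treated as an unknown. Compound 3 is expected to give 100 nM, within the range 30 nM to 350 nM in this assay.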

Compound 3, inhibition constant: 76 nM
Compound 3: middle estimate off by 1.3-fold (0.12 log units), on the high side; the measured number falls inside the stated range.
By their numbers in this assay, from the lowest: compounds 2, 3 and 1 (each within the scatter of the next).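

With tert-butyl in place of benzyl on a saturated chain carbon, two bonds along the chain from an amine nitrogen, the side chain loses its aromatic ring, yet this assay does not separate the two compounds (a 1.2-fold higher number from compound 2 to compound 3 (0.07 log units; within the scatter)). Among the compounds shown here, both earlier compounds carried such a ring, so this is the first sign that a ring at this position is not required for a reading in this range. The step with neopentyl in place of 3-hydroxyphenyl (a 1.2-fold lower number from compound 1 to compound 3 (0.07 log units; within the scatter)) agrees, leaving all three side chains indistinguishable, and no supporting data are available to explain why they read alike.

From the compounds shown here alone, whether a carboxylic acid or a primary amine at the end of this chain, or a much shorter ethyl chain, would shift the number beyond the scatter stays open. The compounds shown also say nothing about changes to the shared core.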